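The source may report more compounds than this note shows. Statements on the series, on what has been measured and on what is new or still open speak of the compounds shown alone.

In a functional assay on HepG2 cells (Homo sapiens) for inhibition, read by MTT assay (a higher number here means a weaker inhibitor, a lower number a stronger inhibitor), compound 1 `COc1cc2ncnc(Nc3ccc(NC(=O)c4ccccc4Cl)cc3)c2cc1OC` gives 26000 nM and compound 2 `COc1cc2ncnc(Nc3ccc(NC(=O)c4ccc(Cl)cc4)cc3)c2cc1OC` gives 28000 nM so these two stand level within the scatter. Compound 3 `COc1cc2ncnc(Nc3ccc(NC(=O)c4ccc(Cl)c(Cl)c4)cc3)c2cc1OC` differs from compound 2 by one change chloro in place of hydrogen on an aromatic carbon with chloro in place of hydrogen on an aromatic carbon, giving 3,4-dichlorophenyl. Going by the values given here, the one measured step that bears on this is a 1.1-fold higher number from compound 1 to compound 2 (0.03 log units; within the scatter) where a chloro group changes place, and it adds no chlorine, so it guides only loosely. No step beyond the scatter is expected in this assay and the estimated step is a 1.2-fold lower number from compound 2 to compound 3 (0.07 log units; within the scatter) for now. Compound 3 is estimated at 24000 nM with an expected range from 10000 nM to 50000 nM in this measure.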

Compound 3, half-maximal inhibitory concentration: 28000 nM
Estimate against measurement, compound 3: 1.2-fold (0.07 log units) below; measured number inside the range.
By their numbers in this assay, from the lowest: compounds 1, 2 and 3 (each within the scatter of the next).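

In this assay, a second chlorine on the ring, giving 3,4-dichlorophenyl, leaves the number level (no change at the digits printed from compound 2 to compound 3 (within the scatter)), whereas the earlier pair showed only a chloro group changing place. The 3,4-dichlorophenyl group also stands level with 2-chlorophenyl (a 1.1-fold higher number from compound 1 to compound 3 (0.03 log units; within the scatter)), so among these three compounds neither the place nor the count of chlorines separates them. Nothing measured here offers a reason for this. Still open, going by these compounds, is whether an amine or a carboxylic acid on this ring, in place of chloro, would shift the number beyond the scatter.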